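Sulfonyl aryl exchange on compound 3: thiophene to pyridine

The compounds below may be only part of what the source reports. "The series", "measured", "known", "first", "only" and "open" are said of these compounds alone.

Three compounds of the series have been run in a functional assay on the whole organism (strain Jcl:SD) for inhibition, with Rattus norvegicus as the target, with stated times of 3 min and 3 h, at a dose of 1 mg/kg by the intravenous route; a lower number here means less inhibition, a higher number more inhibition at the dose given (going by the name of the read-out). Compound 1 `CNCc1cc(-c2cccc(F)c2)n(S(=O)(=O)c2ccc(C)cc2)c1` gives 77%. Compound 2 `CNCc1cc(-c2cccnc2F)n(S(=O)(=O)c2cccc(OC)c2)c1` gives 92%. Compound 3 `CNCc1cc(-c2cccnc2F)n(S(=O)(=O)c2ccsc2)c1` gives 98%. Compound 3 carries the highest of the three numbers as read, but compound 2 lies within the scatter of it; only the gap to compound 1, which differs from compound 3 in two places, is beyond the scatter. Within the data shown here, the one single-point step on the sulfonyl sulfur, a number 6 percentage points higher from compound 2 to compound 3 (within the scatter), stays within the scatter.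

Compound 4 `CNCc1cc(-c2cccnc2F)n(S(=O)(=O)c2cccnc2)c1` is the next single-point change from compound 3: pyridin-3-yl in place of thiophen-3-yl on a sulfonyl sulfur. Among the measured compounds shown here, the only measured step that bears on it is the earlier exchange of the group on the sulfonyl sulfur, a number 6 percentage points higher from compound 2 to compound 3 (within the scatter), which did not move the read-out beyond the scatter. The expectation for compound 4 in this assay is therefore a number within the scatter of compound 3, if anything a little lower because the number for compound 3 98% already leaves little room upward. The step expected is a number 7 percentage points lower from compound 3 to compound 4 (within the scatter). Compound 4 is expected to give 91%, with a range from 76% to 100%.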

Compound 4, a percentage reported as inhibition, in the whole organism at one dose (the size of the read-out at that dose, not a potency): 96%
Compound 4: the middle estimate sits 5 percentage points below what was measured, and the stated range covers the measured number.
By their numbers in this assay, from the lowest: compound 1; then compounds 2, 4 and 3 (each within the scatter of the next).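

In this assay, the step from the five-membered thiophen-3-yl to the six-membered pyridin-3-yl on a sulfonyl sulfur is a number 2 percentage points lower from compound 3 to compound 4 (within the scatter) and the exchange of 3-methoxyphenyl for pyridin-3-yl is a number 4 percentage points higher from compound 2 to compound 4 (within the scatter) at the same place. Among these compounds, the earlier compounds offered only one exchange at this position; now all three pairs among the 3-methoxyphenyl, thiophen-3-yl and pyridin-3-yl compounds are printed within the scatter, so this read-out at this single dose does not separate these three aromatic groups and gives them no order. Nothing at hand explains why the read-out stays level across these exchanges.

On these data alone, the numbers for compound 2, compound 3 and compound 4 all lie near the top of the percentage scale, so it remains open whether these groups would separate at a lower dose. Also open, as far as these compounds go, is whether the read-out would hold with a non-aromatic group such as cyclohexyl, or a small alkyl group such as methyl, on the sulfonyl sulfur.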